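A few compounds are considered here, and "the series" means these few. Any claim that something is new, unique, unknown or untested is made for them only; others in the source may bear on it.

Compounds measured in a functional assay, read by spectrophotometry, with a stated time of 2 h, tested at 1 mg/mL; on this read-out higher numbers stand for a stronger effect at the one concentration tested and lower numbers for a weaker effect:
compound 1 `CC(C)[C@@H]1CC[C@@H](C)C[C@@]12N(C)C(=O)[C@@H]1[C@H]3C(=O)N(c4ccccc4)C(=O)[C@H]3ON12` — 29.7%
compound 2 `CC(C)[C@@H]1CC[C@@H](C)C[C@@]12N(C)C(=O)[C@@H]1[C@H]3C(=O)N(c4ccc(Cl)cc4)C(=O)[C@H]3ON12` — 39.9%
compound 3 `Cc1ccc(N2C(=O)[C@H]3[C@H](ON4[C@@H]3C(=O)N(C)[C@@]43C[C@H](C)CC[C@H]3C(C)C)C2=O)c(C)c1` — 69%

Compound 1 stands lowest of the three in this assay. Its nearest neighbour is compound 2, reached by a number 10.2 percentage points higher from compound 1 to compound 2 (beyond the scatter). Its furthest is compound 3, reached by a number 39.3 percentage points higher from compound 1 to compound 3 (beyond the scatter); between those two, a number 29.1 percentage points higher from compound 2 to compound 3 (beyond the scatter) separates them. Every change so far has been made on the aryl group carried by the amide-type nitrogen in the ring of the shared core, and each has raised the number beyond the scatter.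

Compound 4 `CC(C)[C@@H]1CC[C@@H](C)C[C@@]12N(C)C(=O)[C@@H]1[C@H]3C(=O)N(c4ccc5ccccc5c4)C(=O)[C@H]3ON12` has not yet been measured. It differs from compound 1 in one place: naphthalen-2-yl in place of phenyl on an amide-type nitrogen in a ring. This is again a change on the same aryl group, and the two steps that bear on it, a number 10.2 percentage points higher from compound 1 to compound 2 (beyond the scatter) and a number 39.3 percentage points higher from compound 1 to compound 3 (beyond the scatter), both point upward, the second by a large amount. The account therefore expects an upward step of modest to large size in this assay, estimated as a number 22.3 percentage points higher from compound 1 to compound 4 (beyond the scatter). For compound 4 the expected value is 52%, within a range from 32% to 75%.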

Compound 4, a percentage reported as activity, at one concentration (the size of the read-out at that concentration, not a potency): 33.2%
The estimate for compound 4 lay 18.8 percentage points above the measured number; the measured number falls inside the stated range.
By their numbers in this assay, from the lowest: compounds 1, 4 and 2 (each within the scatter of the next, the first and the last beyond it); then compound 3.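

In this assay, the larger naphthalen-2-yl group on the amide-type nitrogen does not carry the number upward: the result is a number 3.5 percentage points higher from compound 1 to compound 4 (within the scatter), and against the 4-chlorophenyl group it is a number 6.7 percentage points lower from compound 2 to compound 4 (within the scatter). Compound 4 therefore goes against the rise seen with every earlier change at this position, and the added aromatic ring does not reproduce the high number of the 2,4-dimethylphenyl group, as a number 35.8 percentage points lower from compound 3 to compound 4 (beyond the scatter) shows. Nothing measured here accounts for this difference between the aryl groups.

On these data alone, whether the high number of compound 3 depends on both methyl groups or on only one remains open, a question that 2-methylphenyl and 4-methylphenyl would separate. Also open, as far as these compounds go, is how this position responds to a methoxy group or an amine on the phenyl ring, or to a saturated cyclohexyl group in place of the aryl group.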